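Trifluoromethyl in place of iodo: expected maximal response

The compounds below may be only part of what the source reports. "The series", "measured", "known", "first", "only" and "open" are said of these compounds alone.

Compound 1 `O=C(Nc1ccc(S(=O)(=O)Nc2ccccc2)cc1)c1ccc(Cl)cc1F` gives 57% in a functional assay on HEK293 cells for agonist activity at probable G-protein coupled receptor 27 (Homo sapiens), read by a luciferase reporter and beta-arrestin recruitment, with a stated time of 10 min; a lower number here means a smaller maximal response, a higher number a larger maximal response. Going by the values given here, compound 2 `O=C(Nc1ccc(S(=O)(=O)Nc2ccccc2)cc1)c1ccc(I)cc1F` gives 36% in this assay, the lowest of the two numbers; the single measured step, iodo in place of chloro on an aromatic carbon, is a number 21 percentage points lower from compound 1 to compound 2 (beyond the scatter). Compound 3 `O=C(Nc1ccc(S(=O)(=O)Nc2ccccc2)cc1)c1ccc(C(F)(F)F)cc1F` differs from compound 2 by trifluoromethyl in place of iodo on an aromatic carbon. Among the compounds with values here, no measured step covers trifluoromethyl here, so the halogen step only shows that the group at this carbon shifts the maximal response modestly. Compound 3 is expected close to compound 2, with an estimated step of a number 4 percentage points higher from compound 2 to compound 3 (within the scatter). The estimate for compound 3 is 40%, range 20% to 60%.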

Compound 3, largest response reached (Emax), in percent of the reference or control that the assay uses: 50%
Compound 3: middle estimate off by 10 percentage points, on the low side; low and high end bracket the measured number.
By their numbers in this assay, from the lowest: compound 2; then compounds 3 and 1 (each within the scatter of the next).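

Trifluoromethyl in place of iodo gives a number 14 percentage points higher from compound 2 to compound 3 (beyond the scatter), while trifluoromethyl in place of chloro gives a number 7 percentage points lower from compound 1 to compound 3 (within the scatter). Of the three groups at this carbon, para to a large group, only iodo stands apart in this assay, and chloro and trifluoromethyl cannot be told apart. Nothing available accounts for the separate place of iodo.

As far as these compounds go, whether a methoxy group, an amine or a plain hydrogen at this carbon would match compound 1 and compound 3 or compound 2 remains open.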